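Acyl variation on an anilide series, compound 3 to compound 4

This account rests on a few compounds, and the source may have more. Where it says the series, first, only, none or still open, it means among the compounds named here.

Measured compounds:
- compound 1, `COc1ccc(CNc2cc(OC)c(OC)c(OC)c2)cc1[N+](=O)[O-]`: 16800 nM
- compound 2, `C/C=C/C(=O)N(Cc1cc(OC)c(OC)c(OC)c1)c1ccc(OC)c(O)c1`: 9160 nM
- compound 3, `C#CC(=O)N(Cc1ccc(OC)c(O)c1)c1cc(OC)c(OC)c(OC)c1`: 570 nM

All three were run in a functional assay on KYSE-450 cells (Homo sapiens) for inhibition, read by MTT assay, with a stated time of 48 h; a lower number here means a stronger inhibitor, a higher number a weaker inhibitor. Compound 3 holds the lowest number of the three. Its nearest neighbour is compound 2, whose value sits beyond the scatter above it, and compound 1 lies further still, also beyond the scatter. On these numbers compound 3 is the strongest of the set.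

Compound 4, `COc1ccc(CN(C(=O)CCCCCl)c2cc(OC)c(OC)c(OC)c2)cc1O`, has not yet been run in this assay. It differs from compound 3 in one place: 4-chlorobutyl in place of ethynyl on a carbonyl carbon. The carbonyl carbon carrying the new group keeps its other neighbour, the amide-type nitrogen, so the change is confined to the acyl chain, ethynylcarbonyl becoming (4-chlorobutyl)carbonyl.

No measured pair in the set shares exactly this change, so the direction rests on the spread shown. Among the compounds with values here, compound 2, the only other acylated member, and compound 1, which lacks the acyl group altogether, both sit well above compound 3. A step upward in this assay, beyond the scatter, is therefore expected from compound 3 to compound 4, though the loss is not expected to reach the level of compound 1. For compound 4 the expected value in this assay is 6000 nM, with a range of 1500 nM to 25000 nM, corresponding to an expected step of an 11-fold higher number from compound 3 to compound 4 (1.02 log units; beyond the scatter).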

Compound 4, half-maximal inhibitory concentration: 770 nM
Compound 4: middle estimate off by 7.8-fold (0.89 log units), on the high side; the measured number lies below the stated range.
By their numbers in this assay, from the lowest: compounds 3 and 4 (each within the scatter of the next); then compounds 2 and 1 (each within the scatter of the next).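

In this assay, 4-chlorobutyl in place of ethynyl on a carbonyl carbon gives a 1.4-fold higher number from compound 3 to compound 4 (0.13 log units; within the scatter), so this acyl position accepts the exchange with no readable change. The triple bond outside aromatic rings is therefore not required for a number in this range, at least within this pair: the entering chain has no such bond and carries 5 heavy atoms where the leaving group carries 2. No measurement among the data bears on why the two acyl chains read alike.

The compounds shown leave open whether the chlorine or the chain itself carries the result, a question that a plain butyl chain on the same carbonyl carbon would address. Also open, from the compounds shown here alone, is how far the tolerance extends, whether to a longer chain such as 6-chlorohexyl or to an amine or a carboxylic acid in place of the chlorine.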